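A few compounds are considered here, and "the series" means these few. Any claim that something is new, unique, unknown or untested is made for them only; others in the source may bear on it.

In an ADME assay on microsomes from liver (Rattus norvegicus) for metabolic stability, with a stated time of 60 min, tested at 1 uM (a higher number here means that more of the compound is left, a lower number that less of the compound is left), compound 1 (`CNc1nc2c(-c3ccnc(OC)c3)cnn2cc1OC`) gives 74% and compound 2 (`Cn1cc(-c2nc3c(-c4ccnc(OC5CC5)c4)cnn3cc2OCCCC(C)(C)O)cn1`) gives 64%. Going by the values given here, these two values lie within the usual scatter of each other, so the data cannot separate compound 1 from the only other measured compound. Compound 3 (`COc1cnc2c(-c3ccnc(OC)c3)cnn2c1`) is compound 1 with a single change, hydrogen in place of methylamino on an aromatic carbon. Among the compounds with values here, no two measured compounds differ in just one place, so the data offer no direct guide to the size of this step. With so little to go on, no change beyond the scatter is expected in either direction, although the uncertainty is wide. The expected change is a number 4 percentage points lower from compound 1 to compound 3 (within the scatter). In this assay, the estimated value for compound 3 is 70%, with an expected range from 48% to 88%.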

Compound 3, percent of the compound remaining: 10%
Beside the measured number, compound 3's estimate is 60 percentage points above it; the whole stated range lies above it.
By their numbers in this assay, from the lowest: compound 3; then compounds 2 and 1 (each within the scatter of the next).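

In this assay, going by these compounds alone, putting hydrogen in place of methylamino on this aromatic carbon brings a number 64 percentage points lower from compound 1 to compound 3 (beyond the scatter) and so gives the first direct reading of a single change. The position, next to the ring nitrogen and ortho to a methoxy group, is therefore far from neutral: what sits there can strongly affect how much compound is left, something the two earlier compounds, which differ in several places, could not show. No measurement shown here bears on why this step is so large.

As far as these compounds go, it remains open whether methylamino itself matters or whether other groups on this carbon would do the same. A plain amino group, an ethylamino group, a methyl group or a fluorine atom at this position would help separate these possibilities.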